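The source may report more compounds than this note shows. Statements on the series, on what has been measured and on what is new or still open speak of the compounds shown alone.

Working notes on the series. Compound 1 `Cc1nc(C(=O)Nc2ccc(Cl)c(-c3nnc4c(Cl)cccn34)c2)cs1` carries a 2-methyl-1,3-thiazol-4-yl group on the carbonyl carbon of the shared core. In a functional assay on AN3-CA cells (Homo sapiens) for antiproliferative activity, read by MTT assay, with a stated time of 72 h (on this read-out lower numbers stand for stronger inhibition and higher numbers for weaker inhibition), compound 1 reaches only > 100000 nM, which is a limit of the assay and not a number. Compound 2 `O=C(Nc1ccc(Cl)c(-c2nnc3c(Cl)cccn23)c1)c1ccc(Cl)cc1Cl` replaces that group with 2,4-dichlorophenyl, and in this assay compound 2 gives 84800 nM. The step of an at least 1.1-fold lower number from compound 1 to compound 2 (0.07 log units; that floor lies within the scatter) is therefore a change at the carbonyl carbon that does not move the read-out beyond the scatter. Among the measured compounds shown here, compound 2 thus stands as the only compound with a genuine number in this assay; the other entry is a limit (the limit of > 100000 nM in this assay, at which 1 of the 2 values shown sits).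

Compound 3 `O=C(Nc1ccc(Cl)c(-c2nnc3c(Cl)cccn23)c1)c1c(F)cccc1Cl` has not been measured in this assay. It differs from compound 2 by 2-chloro-6-fluorophenyl in place of 2,4-dichlorophenyl on a carbonyl carbon. For the measured compounds named here, the only measured step at this position, from compound 1 to compound 2, stayed within the scatter, so the expected step of a 1.1-fold lower number from compound 2 to compound 3 (0.03 log units; within the scatter) is small and without a clear direction. Compound 3 is estimated at 80000 nM, with a range from 30000 nM to 100000 nM.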

Compound 3, half-maximal inhibitory concentration: > 100000 nM
Compound 3 gave a limit, no number; the forecaster's own chance of this, stated with the estimate: 40%; middle value at least 1.2-fold (0.09 log units) away from the limit.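

In this assay, the change on a carbonyl carbon whose other neighbour is the amide-type nitrogen gives an at least 1.1-fold higher number from compound 2 to compound 3 (0.07 log units; that floor lies within the scatter), so the readable part of this step stays within the scatter, and the limit leaves its full size open. Moving the chlorine pattern and bringing in fluorine on the phenyl ring therefore shows no step beyond the scatter at this position, and the step from compound 1 to compound 3 cannot be read. Across the 2-methyl-1,3-thiazol-4-yl, 2,4-dichlorophenyl and 2-chloro-6-fluorophenyl groups, the position has yielded a genuine number only for compound 2, and the rest of the series sits at a limit: the limit of > 100000 nM in this assay, at which 2 of the 3 values shown sit.

As far as these compounds go, whether any group on this carbonyl carbon can bring the read-out clearly away from that limit remains open. The compounds shown also leave open what an amine or a carboxylic acid on a longer chain would do at this place, and whether a change elsewhere on the shared core would do more than any change here.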